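The source may report more compounds than this note shows. Statements on the series, on what has been measured and on what is new or still open speak of the compounds shown alone.

Compound 1 `CC/C(=C(/c1ccc(/C=C/C(=O)O)cc1)c1cc2ccccc2[nH]1)c1ccccc1Cl`: 42 nM
Compound 2 `CC/C(=C(/c1ccc(/C=C/C(=O)O)cc1)c1cc2ccccc2[nH]1)c1cccc(C(F)(F)F)c1`: 325 nM
Compound 3 `CC/C(=C(/c1ccc(/C=C/C(=O)O)cc1)c1cc2ccccc2[nH]1)c1ccc(F)cc1Cl`: 39 nM

These three compounds share one core and differ only in the aromatic ring that sits on a double-bonded chain carbon. In a functional assay on MCF7 cells (Homo sapiens) for inhibition (on this read-out lower numbers stand for stronger inhibition and higher numbers for weaker inhibition), compound 3 gives the lowest number of the three. Compound 1 is its nearest neighbour, with a 1.1-fold lower number from compound 1 to compound 3 (0.03 log units; within the scatter) between them, while compound 2 stands furthest away, with an 8.3-fold lower number from compound 2 to compound 3 (0.92 log units; beyond the scatter).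

Compound 4 `CC/C(=C(/c1ccc(/C=C/C(=O)O)cc1)c1cc2ccccc2[nH]1)c1cc(Cl)ccc1Cl` has not yet been measured. It differs from compound 3 in one place: 2,5-dichlorophenyl in place of 2-chloro-4-fluorophenyl on a double-bonded chain carbon bound to a double-bonded chain carbon and a saturated chain carbon. Among the compounds with values here, two measured steps bear on this. Adding a fluoro to the ring of compound 1 gave a 1.1-fold lower number from compound 1 to compound 3 (0.03 log units; within the scatter), whereas swapping the whole ring for a 3-(trifluoromethyl)phenyl gave a 7.7-fold higher number from compound 1 to compound 2 (0.89 log units; beyond the scatter). Compound 4 keeps a 2-chloro-substituted ring and only exchanges one halogen for another, so the small step of a 1.1-fold lower number from compound 1 to compound 3 (0.03 log units; within the scatter) is the closer guide. Compound 4 is therefore expected to move by a 1.3-fold higher number from compound 3 to compound 4 (0.11 log units; within the scatter) in this assay. Compound 4 is estimated at 50 nM, within a range from 20 nM to 130 nM.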

Compound 4, half-maximal inhibitory concentration: 71 nM
Compound 4: the middle estimate sits 1.4-fold (0.15 log units) below what was measured; the range from low to high includes it.
By their numbers in this assay, from the lowest: compounds 3, 1 and 4 (each within the scatter of the next); then compound 2.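

In this assay a second chlorine on the ring at this place changes little: adding it gives a 1.7-fold higher number from compound 1 to compound 4 (0.23 log units; within the scatter) and exchanging the 2-chloro-4-fluorophenyl for 2,5-dichlorophenyl gives a 1.8-fold higher number from compound 3 to compound 4 (0.26 log units; within the scatter) so both steps stay inside the scatter. Compound 1, compound 3 and compound 4 therefore form one group of rings carrying a chlorine, while the 3-(trifluoromethyl)phenyl ring stands apart, with a 4.6-fold lower number from compound 2 to compound 4 (0.66 log units; beyond the scatter) beyond the scatter. Nothing available explains why these rings behave as they do.

The step from compound 2 replaces the whole ring, so it leaves open how much depends on the chlorine and how much on the trifluoromethyl. An unsubstituted phenyl, or a ring bearing a methoxy or an amine, would help to separate these.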